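A few compounds are considered here, and "the series" means these few. Any claim that something is new, unique, unknown or untested is made for them only; others in the source may bear on it.

Compound 1, `O=C(Nc1ccc(Cl)cc1)c1cc(Oc2ccc(/C=C/c3ccccn3)cc2)ccn1`, compound 2, `O=C(NCc1ccccc1)c1cc(Oc2ccc(/C=C/c3ccccn3)cc2)ccn1`, and compound 3, `O=C(Nc1ccc(Cl)cc1)c1cc(Oc2ccc(/C=C/c3ccncc3)cc2)ccn1`, were tested in a functional assay on A549 cells (Homo sapiens) for antiproliferative activity, read by CCK-8 assay, with a stated time of 48 h; on this read-out higher numbers stand for weaker inhibition and lower numbers for stronger inhibition. In this assay compound 1 gives 16200 nM, compound 2 gives 18800 nM, and compound 3 gives 62100 nM. The change from compound 1 to compound 2 is benzyl in place of 4-chlorophenyl on an amide-type nitrogen, and it made a step of a 1.2-fold higher number from compound 1 to compound 2 (0.06 log units; within the scatter). Compound 3 differs from compound 1 in its core, by pyridin-4-yl in place of pyridin-2-yl on a double-bonded chain carbon bound to a double-bonded chain carbon, a change that made a step of a 3.8-fold higher number from compound 1 to compound 3 (0.58 log units; beyond the scatter), so that compound 3 carries the highest of the three numbers.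

Compound 4, `O=C(NCc1ccccc1)c1cc(Oc2ccc(/C=C/c3ccncc3)cc2)ccn1`, has not yet been measured. It differs from compound 3 by benzyl in place of 4-chlorophenyl on an amide-type nitrogen, which is the same change as that between compound 1 and compound 2, made on the same amide-type nitrogen whose other neighbour is a carbonyl carbon. Because that earlier step was a 1.2-fold higher number from compound 1 to compound 2 (0.06 log units; within the scatter), the expected step for compound 4 is a 1.1-fold higher number from compound 3 to compound 4 (0.05 log units; within the scatter), beside the earlier one. Resting on compound 3 and its value 62100 nM, compound 4 is estimated to give 70000 nM in this assay, between 30000 nM and 160000 nM.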

Compound 4, half-maximal inhibitory concentration: 17000 nM
Compound 4: middle estimate off by 4.1-fold (0.61 log units), on the high side; measured number outside the range, below it.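

In this assay, benzyl in place of 4-chlorophenyl on the amide-type nitrogen now gives a 3.7-fold lower number from compound 3 to compound 4 (0.56 log units; beyond the scatter), so this change did not carry over from the core of compound 1 to the core of compound 3 with the same size or direction: the same change on two cores in this assay, a 1.2-fold higher number (0.06 log units; within the scatter) from compound 1 to compound 2 and a 3.7-fold lower number (0.56 log units; beyond the scatter) from compound 3 to compound 4, 4.2-fold (0.63 log units) apart, beyond the scatter of two such steps. Read the other way, pyridin-4-yl in place of pyridin-2-yl gives a 1.1-fold lower number from compound 2 to compound 4 (0.04 log units; within the scatter) when benzyl sits on that nitrogen, so the effect of this change also depends on the group on the amide-type nitrogen: the same change on two cores in this assay, a 3.8-fold higher number (0.58 log units; beyond the scatter) from compound 1 to compound 3 and a 1.1-fold lower number (0.04 log units; within the scatter) from compound 2 to compound 4, 4.2-fold (0.63 log units) apart, beyond the scatter of two such steps. Among these compounds, this shows that the two changes do not add up in this set, but both gaps rest on the one high value of compound 3, 62100 nM, and a single set of four compounds does not show how far such dependence extends through the series.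

The compounds shown leave open whether the same dependence would appear with pyridin-3-yl on the double-bonded chain carbon, or with unsubstituted phenyl or a longer chain such as phenethyl on the amide-type nitrogen. They also leave open what lies behind the dependence and whether it holds outside this assay.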